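A few compounds are considered here, and "the series" means these few. Any claim that something is new, unique, unknown or untested is made for them only; others in the source may bear on it.

Of the compounds shown here, two have been measured so far in an ADME assay on MDBK cells (Bos taurus) for cytotoxicity, read by MTT assay, with a stated time of 96 h (on this read-out lower numbers stand for higher toxicity in this test and higher numbers for lower toxicity in this test), and they stand as follows.

- Compound 1 `O=[N+]([O-])c1ccc(-c2nc3cc(C(F)(F)F)ccc3n2C2CCCCC2)cc1` gives 68000 nM
- Compound 2 `Cn1c(-c2ccc(N)cc2)nc2cc(C(F)(F)F)ccc21` gives 74000 nM

Compound 2, at 74000 nM in this test, lies within the usual scatter of compound 1, so the two numbers count as level and neither compound can be called the less toxic one. The next compound is compound 3 `Nc1ccc(-c2nc3cc(C(F)(F)F)ccc3n2C2CCCCC2)cc1` which carries cyclohexyl in place of methyl on an aromatic nitrogen, counted in full as cyclohexyl in place of methyl on an aromatic nitrogen against compound 2. Going by the values given here, no two measured compounds differ in one place only, so the size of this change has not been seen on its own. Among the compounds with values here, the only hint is compound 1, which also carries cyclohexyl on that nitrogen and gives 68000 nM as its value, level with the methyl-bearing compound 2. A small move towards a lower number in this assay is therefore expected, perhaps none beyond the scatter. The estimated step is a 1.5-fold lower number from compound 2 to compound 3 (0.17 log units; within the scatter) and no more than that. For compound 3 the estimated value is 50000 nM with 15000 nM to 100000 nM as the expected range.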

Compound 3, half-maximal cytotoxic concentration: > 100000 nM
Compound 3: only a limit was reported (the forecaster's own chance of this, stated with the estimate: 20%); middle value at least 2.0-fold (0.30 log units) away from the limit.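

For compound 3 the reading in this assay is a limit and not a number: the limit of > 100000 nM in this assay, at which 1 of the 3 values shown sits. Going by these compounds alone, compound 3 still gives the first view of cyclohexyl in place of methyl on an aromatic nitrogen as a single change, with the 4-aminophenyl group kept the same, and that change gives an at least 1.3-fold higher number from compound 2 to compound 3 (0.13 log units; that floor lies within the scatter); the larger ring on this nitrogen therefore does not bring the lower number that the earlier compounds hinted at, although the true size of the step stays unknown. With cyclohexyl kept on that nitrogen, amino in place of nitro on an aromatic carbon gives an at least 1.4-fold higher number from compound 1 to compound 3 (0.16 log units; that floor lies within the scatter), a second single change that can also be read only as a floor.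

Both steps are floors, and the compounds shown cannot rank one change against the other or say why either number stands where it does. As far as these compounds go, it also stays open whether an ethyl group or a longer chain on the same nitrogen, or a carboxylic acid in place of the amino group, would leave the number at this level.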